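Three Aminothiophene Ketones and a Fourth Still to Test

This account rests on a few compounds, and the source may have more. Where it says the series, first, only, none or still open, it means among the compounds named here.

Compound 1 `CC(C)(C)Cc1c(-c2ccccn2)sc(N)c1C(=O)c1ccc(Cl)cc1` was tested in an assay on CHO cells for displacement of a labelled ligand from adenosine receptor A3 (Homo sapiens), read by scintillation counting, tested at 10 uM (a higher number here means more inhibition at the concentration tested (going by the name of the read-out), a lower number less inhibition), where compound 1 gives 1%. Two companions of the same core were measured alongside it. Compound 2 `CC(C)(C)Cc1c(-c2ccccc2)sc(N)c1C(=O)c1cccc(C(F)(F)F)c1` gives 1% in this assay, and compound 3 `Cc1ccc(C(=O)c2c(N)sc(-c3ccccc3)c2CC(C)(C)C)cc1` gives 1%. Compound 1 thus stands level with compounds 2 and 3 at the digits reported: its nearest neighbour on the numbers is compound 2, with no change at the digits reported, and its furthest is compound 3, likewise with no change, both within the scatter of this kind of measurement.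

The step from compound 1 leads to compound 4 `COc1ccc(-c2sc(N)c(C(=O)c3ccc(Cl)cc3)c2CC(C)(C)C)cc1`, which has not yet been measured. The change is 4-methoxyphenyl in place of pyridin-2-yl on an aromatic carbon. The group that leaves is one six-membered aromatic ring with one hetero atom; the group that enters is one six-membered aromatic ring of carbon only.

Among the compounds with values here, no step between two measured compounds is available to gauge this kind of change. All three measured compounds, including compounds 2 and 3 with a phenyl group on the same ring, sit at the bottom of the scale, so the step in this assay is expected to be none beyond the scatter, in neither direction. Compound 4 is therefore expected to give 3%, with a range from -8% to 15%. The expected step of a number 2 percentage points higher from compound 1 to compound 4 (within the scatter) accordingly lies within the scatter.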

Compound 4, a percentage reported as inhibition, at one concentration (the size of the read-out at that concentration, not a potency): 2%
Estimate against measurement, compound 4: 1 percentage points above, and the stated range covers the measured number.
By their numbers in this assay, from the lowest: compounds 1, 2, 3 and 4 (each within the scatter of the next).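

Within the data shown here, exchanging pyridin-2-yl for 4-methoxyphenyl on the aromatic carbon next to the ring sulfur gives the first step that can be read at this position: in this assay, the result is a number 1 percentage points higher from compound 1 to compound 4 (within the scatter). The ring nitrogen is gone and the group grows from 6 heavy atoms to 8, yet with compound 4 at 2%, this exchange does not lift the read-out clear of the scatter on the shared core. Nothing measured here bears on why the step has this size.

The compounds shown leave open whether any group at this position can produce a step beyond the scatter, since a single exchange with a low value at both ends says little about the position as a whole. A piperidine or a carboxylic acid on this aromatic carbon, or a longer chain in place of the neopentyl group, would test that more widely than another aromatic ring of this size.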